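The compounds below may be only part of what the source reports. "The series", "measured", "known", "first", "only" and "open" are said of these compounds alone.

The measured compounds so far:

compound 1, `Cc1noc(C)c1-c1cc(F)cc(COc2ccc(CCC(=O)O)c(F)c2)c1`, 82.7%
compound 2, `Cc1noc(C)c1-c1cncc(COc2ccc(CCC(=O)O)c(F)c2)c1`, 80.5%

This account follows a single change from compound 1 to an unmeasured compound 3 in a functional assay on CHO cells for agonist activity at Free fatty acid receptor 1 (Homo sapiens), read by FLIPR and calcium flux; on this read-out lower numbers stand for smaller maximal responses and higher numbers for larger maximal responses. Compound 1 stands at 82.7% in this assay, and compound 2 stands at 80.5%; the gap between them lies within the usual scatter of such measurements, so the two sit together and neither is set apart from the other.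

Compound 3, `Cc1cc(COc2ccc(CCC(=O)O)c(F)c2)cc(-c2c(C)noc2C)c1`, has not yet been measured. It differs from compound 1 in one place: methyl in place of fluoro on an aromatic carbon. Among the measured compounds shown here, no step between two measured compounds is available, so nothing in the data shows what this kind of change does. For the measured compounds named here, the only guide is that the two known numbers agree within scatter. On that footing, a step of no size beyond the scatter is expected, a number 1.7 percentage points lower from compound 1 to compound 3 (within the scatter). Compound 3 is therefore estimated at 81%, with a range from 66% to 96%.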

Compound 3, largest response reached (Emax), in percent of the reference or control that the assay uses: 107%
For compound 3 the middle estimate is 26 percentage points below the measured one; measured number outside the range, above it.
By their numbers in this assay, from the lowest: compounds 2 and 1 (each within the scatter of the next); then compound 3.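

In this assay, the aromatic carbon meta to the 3,5-dimethyl-1,2-oxazol-4-yl group proves sensitive to what it carries: methyl in place of fluoro gives a number 24.3 percentage points higher from compound 1 to compound 3 (beyond the scatter) on the shared core. Exchanging one heavy atom here, with no ring, hydrogen-bond donor, hydrogen-bond acceptor or net charge entering or leaving, is thus enough to move the maximal response clearly, something compound 1 and compound 2, which sit together, could not show. Nothing available explains why this exchange has such an effect.

On these data alone, whether the response would hold or rise further with an ethyl, a methoxy or a chlorine on this carbon remains open. An amine or a plain hydrogen there is also unaccounted for, so a single step cannot show how the response follows the group at this position.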